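Aryl swap on the anilino nitrogen of a quinazoline-like scaffold

The source may report more compounds than this note shows. Statements on the series, on what has been measured and on what is new or still open speak of the compounds shown alone.

Measured compounds:
- compound 1, `Fc1cccc(Nc2nc(-c3cccc(F)c3)nc3ccc(F)cc23)c1`, > 50000 nM
- compound 2, `Fc1cccc(-c2nc(Nc3ccccc3Cl)c3cc(F)ccc3n2)c1`, > 50000 nM

Compound 1 carries a 3-fluorophenyl on the nitrogen on the aromatic ring. In a functional assay on HT29-AK cells (Homo sapiens) for cytotoxicity, read by MTT assay, with a stated time of 48 h (on this read-out lower numbers stand for stronger inhibition and higher numbers for weaker inhibition), compound 1 gives only a limit, > 50000 nM. Compound 2 carries a 2-chlorophenyl at that nitrogen, and in this assay compound 2 likewise gives only a limit, > 50000 nM. The step that the two limits leave unreadable from compound 1 to compound 2 is therefore not readable in size; both values sit at the limit of > 50000 nM in this assay, at which 2 of the 2 values shown sit.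

Compound 3, `Fc1cccc(-c2nc(Nc3ccc(Br)cc3)c3cc(F)ccc3n2)c1`, has not yet been measured in this assay. It differs from compound 2 by 4-bromophenyl in place of 2-chlorophenyl on a nitrogen on an aromatic ring. Among the measured compounds shown here, the only measured step on this nitrogen, the one from compound 1 to compound 2, gives no readable size, so there is no number that would suggest that exchanging one halogenated phenyl for another moves the read-out away from the limit. For compound 3 the expectation is therefore a step that the limit leaves unreadable from compound 2 to compound 3 that cannot be told from the scatter, and most likely again a limit. Compound 3 is estimated at 60000 nM, within 25000 nM to 150000 nM.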

Compound 3, half-maximal inhibitory concentration: > 50000 nM
Compound 3: only a limit was reported; the forecaster's own chance of this, stated with the estimate: 85%; the middle value lies beyond the limit too.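

In this assay compound 3 also gives only a limit, so no step among compound 1, compound 2 and compound 3 can be read, and all three sit at the same limit: the limit of > 50000 nM in this assay, at which 3 of the 3 values shown sit.

The compounds shown leave open how far beyond that limit each one lies, and whether any other aryl group on this nitrogen would give a measurable value in this assay.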